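A Larger Aryl Group on the Shared Core

The source may hold more compounds than are shown below. What is called first, only, known or untested is meant among the compounds shown, and "the series" means these compounds.

Compound 2 `Nc1ncnc2c1nc(NCc1cccc(Cl)c1)n2[C@@H]1O[C@H](CO)[C@@H](O)[C@H]1O` gives 5400 nM in an assay on COS-7 cells for inhibition of sodium/nucleoside cotransporter 2 (Homo sapiens), read by scintillation counting, in the presence of a further agent that is not named here (on this read-out higher numbers stand for weaker inhibition and lower numbers for stronger inhibition), the second highest of the three numbers measured. Compound 1 `Cc1ccccc1CNc1nc2c(N)ncnc2n1[C@@H]1O[C@H](CO)[C@@H](O)[C@H]1O` gives 65000 nM in this assay, and compound 3 `Nc1ncnc2c1nc(NCc1ccc(-c3ccccc3)cc1)n2[C@@H]1O[C@H](CO)[C@@H](O)[C@H]1O` gives 640 nM. Among the compounds with values here, the one measured step among them, a 12-fold lower number from compound 1 to compound 2 (1.08 log units; beyond the scatter), shows that exchanging the aryl group on this saturated chain carbon can shift the number well beyond the scatter, and the value of compound 3 lies lower again. Compound 4 `Nc1ncnc2c1nc(NCc1cccc3ccccc13)n2[C@@H]1O[C@H](CO)[C@@H](O)[C@H]1O` differs from compound 2 by naphthalen-1-yl in place of 3-chlorophenyl on a saturated chain carbon bound to a nitrogen on an aromatic ring. Since the group on compound 3 goes with 640 nM, a lower number is expected for compound 4, by a 3.6-fold lower number from compound 2 to compound 4 (0.56 log units; beyond the scatter). Compound 4 is therefore estimated at 1500 nM, within 400 nM to 6000 nM.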

Compound 4, half-maximal inhibitory concentration: 5700 nM
The estimate for compound 4 lay 3.8-fold (0.58 log units) below the measured number, within the range that was stated.
By their numbers in this assay, from the lowest: compound 3; then compounds 2 and 4 (each within the scatter of the next); then compound 1.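

With a 1.1-fold higher number from compound 2 to compound 4 (0.02 log units; within the scatter) in this assay naphthalen-1-yl and 3-chlorophenyl cannot be told apart at this position, despite the second aromatic ring. The step of an 11-fold lower number from compound 1 to compound 4 (1.06 log units; beyond the scatter) shows that naphthalen-1-yl still stands far from 2-methylphenyl, yet a second ring alone does not reach compound 3 at 640 nM. Nothing measured here explains either step. The compounds shown leave open how a cyclohexyl group or a carboxylic acid on the aryl group would read on this saturated chain carbon.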